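A few compounds are considered here, and "the series" means these few. Any claim that something is new, unique, unknown or untested is made for them only; others in the source may bear on it.

In an assay on cells for displacement of a labelled ligand from Orexin receptor type 2 (Homo sapiens), read by scintillation counting, with stated times of 10 min and 90 min, tested at 10 uM (on this read-out lower numbers stand for less inhibition and higher numbers for more inhibition at the one concentration tested (going by the name of the read-out)), three compounds have been measured:

Compound 1 `COC(=O)c1ccc2c(C(=O)c3ccccc3)cc(C(=O)c3ccccc3)c-2cc1` gives -14.5%.
Compound 2 `COC(=O)c1cccc2c(C(=O)c3ccccc3)cc(C(=O)c3ccc(C(F)(F)F)cc3)c-2c1` gives 27%.
Compound 3 `O=C(O)c1ccc2c(C(=O)c3ccccc3)cc(C(=O)c3ccccc3)c-2cc1` gives 27%.

Compound 3 differs from compound 1 by hydrogen in place of methyl on an oxygen next to a carbonyl group, and this change gave a number 41.5 percentage points higher from compound 1 to compound 3 (beyond the scatter). Compound 2 stands level with compound 3 at the digits given, within the scatter, and its value lies above that of compound 1; the difference between the core of compound 2 and the core of compound 1 is not broken down here.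

Compound 4 `O=C(O)c1cccc2c(C(=O)c3ccccc3)cc(C(=O)c3ccc(C(F)(F)F)cc3)c-2c1` has not yet been measured in this assay. It differs from compound 2 by hydrogen in place of methyl on an oxygen next to a carbonyl group, the same kind of change as from compound 1 to compound 3, made at the same kind of place. If it carries over, compound 4 is expected to give a step of a number 28 percentage points higher from compound 2 to compound 4 (beyond the scatter), resting on the step of a number 41.5 percentage points higher from compound 1 to compound 3 (beyond the scatter) seen from a single pair. Compound 4 is therefore estimated at 55%, likely between 25% and 80%.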

Compound 4, a percentage reported as inhibition, at one concentration (the size of the read-out at that concentration, not a potency): 26.4%
The estimate for compound 4 lay 28.6 percentage points above the measured number; low and high end bracket the measured number.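

In this assay, the change from methoxycarbonyl to carboxy on the second core gave a number 0.6 percentage points lower from compound 2 to compound 4 (within the scatter). Set beside the earlier step, this shows that the effect of the same change was not carried from one core to the other in this series: the same change on two cores in this assay, a number 41.5 percentage points higher (beyond the scatter) from compound 1 to compound 3 and a number 0.6 percentage points lower (within the scatter) from compound 2 to compound 4, 42.1 percentage points apart, beyond the scatter of two such steps The result rests on only two pairs, however, and it shows neither which of the several differences between the cores of compound 1 and compound 2 matters nor how the change would behave on a third core.

The compounds shown leave open whether the trifluoromethyl group or the different place of the ester on the core accounts for the gap between the two steps. They also leave open how an amide or an ethyl ester would read in place of the methoxycarbonyl or carboxy group on either core.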